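Hydroxy to methoxy from compound 2

The source may hold more compounds than are shown below. What is called first, only, known or untested is meant among the compounds shown, and "the series" means these compounds.

In a functional assay on HepG2 cells (Homo sapiens) for cytotoxicity, read by sulforhodamine B assay, with a stated time of 48 h (a lower number here means a stronger inhibitor, a higher number a weaker inhibitor), compound 1 `COc1cc(/C=C/C(=O)c2cccc(-c3cccc(F)c3)c2)ccc1O` gives 6830 nM. For compound 2 `COc1ccc(/C=C/C(=O)c2cccc(-c3cccc(F)c3)c2)cc1O` the entry reads "not determined" (no result reported), so compound 2 stands without a single number. Compound 3 `COc1ccc(/C=C/C(=O)c2cccc(-c3cccc(F)c3)c2)cc1OC` follows by one change, (methyl in place of hydrogen on an oxygen on an aromatic ring), with methyl in place of hydrogen on an oxygen on an aromatic ring, hydroxy to methoxy. For the measured compounds named here, no measured step exists for this change, so the only anchor is compound 1 at 6830 nM. In this assay a step no larger than the scatter is expected, with no favoured direction. Compound 3 is estimated at 8000 nM, with an expected range of 3000 nM to 25000 nM.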

Compound 3, half-maximal inhibitory concentration: 1170 nM
Compound 3: the middle estimate sits 6.8-fold (0.83 log units) above what was measured, and the stated range ends above it.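

In this assay, methyl in place of hydrogen on an oxygen on an aromatic ring gives a 5.8-fold lower number from compound 1 to compound 3 (0.77 log units; beyond the scatter), so this change is not silent at this position when read from compound 1. The step from compound 2 to compound 3 cannot be read, since compound 2 has no number. Nothing measured here bears on why the number falls. Open, on these data alone, is whether the trend continues with a longer chain such as ethoxy on that oxygen. Also open, as far as these compounds go, is how an amine or a carboxylic acid in that place would read.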